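Swapping a Propanoyl Group for Hydrogen on Compound 1

A few compounds are considered here, and "the series" means these few. Any claim that something is new, unique, unknown or untested is made for them only; others in the source may bear on it.

In a functional assay on U-373MG ATCC cells (Homo sapiens) for inhibition, read by MTT assay, with a stated time of 72 h (on this read-out lower numbers stand for stronger inhibition and higher numbers for weaker inhibition), compound 1 `CCC(=O)O[C@@H](/C(C)=C/[C@@H](C)c1oc(CC)c(C)c(=O)c1C)[C@H](C)[C@@H](OC(=O)CC(C)C)[C@@H](C)c1oc([C@@H](C)[C@@H](O)CC)c(C)c(=O)c1C` gives 21000 nM and compound 2 `CCc1oc([C@H](C)/C=C(\C)[C@H](OC(C)=O)[C@H](C)[C@@H](OC(=O)CC(C)C)[C@@H](C)c2oc([C@@H](C)[C@H](CC)OC(C)=O)c(C)c(=O)c2C)c(C)c(=O)c1C` gives 32000 nM as its value; these two numbers lie within the usual scatter of each other. Compound 3 `CCC(=O)[C@@H](C)c1oc([C@H](C)[C@@H]2O[C@](O)([C@@H](C)c3oc(CC)c(C)c(=O)c3C)[C@@H](C)[C@@H](O)[C@@H]2C)c(C)c(=O)c1C` gives only a limit of > 100000 nM in this assay and no number. Compound 4 `CCc1oc([C@H](C)/C=C(\C)[C@H](O)[C@H](C)[C@@H](OC(=O)CC(C)C)[C@@H](C)c2oc([C@@H](C)[C@@H](O)CC)c(C)c(=O)c2C)c(C)c(=O)c1C` has hydrogen in place of propanoyl on an oxygen on a saturated carbon, so propanoyloxy becomes hydroxy. Among the compounds with values here, no measured pair of compounds shows this change on its own, so the expectation is tentative: a slight move towards weaker inhibition, perhaps no larger than the scatter. The estimated step of a 1.4-fold higher number from compound 1 to compound 4 (0.15 log units; within the scatter) is correspondingly small. For compound 4 the estimated value is 30000 nM with an expected range from 11000 nM to 80000 nM as the span of likely results.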

Compound 4, half-maximal inhibitory concentration: > 100000 nM
Compound 4 ended at the assay's limit (the forecaster's own chance of this, stated with the estimate: 20%); at least 3.3-fold (0.52 log units) between middle value and limit.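

In this assay, within the data shown here, replacing propanoyloxy with hydroxy on this saturated carbon gives an at least 4.7-fold higher number from compound 1 to compound 4 (0.67 log units; beyond the scatter), so this is the first sign that the group on this oxygen affects inhibition. Compound 4 gives a limit and not a number, so the step is only a minimum and its full size stays unknown: the limit of > 100000 nM in this assay, at which 2 of the 4 values shown sit.

The compounds shown leave open whether the inhibition depends on propanoyl itself. A longer butanoyl chain or a small methyl ether on the same oxygen could help to settle this.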